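This account rests on a few compounds, and the source may have more. Where it says the series, first, only, none or still open, it means among the compounds named here.

Among the compounds with values here, in an assay on isolated protein for inhibition of Nicotinamide N-methyltransferase (Homo sapiens), read by luminescence, with a stated time of 20 min (on this read-out lower numbers stand for stronger inhibition and higher numbers for weaker inhibition), compound 2, with the structure `CNc1cc(Cl)c(C(N)=O)cn1`, gives 639 nM, the only number reported in this set. Compound 1, with the structure `C[C@H]1Cc2cc(C(N)=O)cnc2N1`, gives only > 10000 nM in this assay, a limit rather than a number; (the limit of > 10000 nM in this assay, at which 1 of the 2 values shown sits). Compound 2 therefore stands as the single measured point from which a step can be followed. Compound 3, with the structure `CNc1cc(C)c(C(N)=O)cn1`, has not been measured in this assay. It differs from compound 2 by methyl in place of chloro on an aromatic carbon. Within the data shown here, no measured step between two compounds of this set is available, so the size of the change can only be expected, not read. A methyl in place of chloro on an aromatic carbon is expected to shift this assay little, with a step from compound 2 to compound 3 of a 1.6-fold higher number from compound 2 to compound 3 (0.19 log units; within the scatter) that stays near or just beyond the usual scatter. Compound 3 is estimated at 1000 nM, between 300 nM and 3500 nM.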

Compound 3, half-maximal inhibitory concentration: 282 nM
Compound 3: middle estimate off by 3.5-fold (0.55 log units), on the high side; the measured number lies below the stated range.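

In this assay, within the data shown here, methyl in place of chloro on an aromatic carbon gives a 2.3-fold lower number from compound 2 to compound 3 (0.36 log units; beyond the scatter), the only step in this set that can be read between two measured compounds. It shows that this position, ortho to a carbamoyl group and opposite the ring nitrogen, responds to a single-atom exchange by more than the scatter, and that chloro is not needed there for the number to stay in this range. The values shown offer no measured basis for explaining the size or direction of this step.

Going by these compounds, this single pair sets no trend, so it remains open how the number would move with methoxy, fluoro, an amine or a longer chain at this position. On these data alone, it is equally open whether the same exchange would give a step of similar size on the core of compound 1.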